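Bromo for chloro from compound 3 to compound 4

The source may hold more compounds than are shown below. What is called first, only, known or untested is meant among the compounds shown, and "the series" means these compounds.

Measured so far in a functional assay on SK-MEL-28 cells (Homo sapiens) for cytotoxicity, read by MTT assay, with a stated time of 72 h (on this read-out higher numbers stand for weaker inhibition and lower numbers for stronger inhibition), and reported here:
Compound 1 `CSc1nc(Cl)c(C(=O)c2ccccc2)s1` gives > 100000 nM as a limit of the assay
Compound 2 `CSc1nc(Br)c(C(=O)c2ccccc2)s1` gives > 100000 nM as a limit of the assay
Compound 3 `O=C(c1ccccc1)c1sc(N2CCCC2)nc1Cl` gives 98000 nM as an actual number

Compound 3 is the only one of the three with a number. Compound 1 and compound 2 stand at the limit of > 100000 nM in this assay, at which 2 of the 3 values shown sit, and have no number.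

Compound 4 `O=C(c1ccccc1)c1sc(N2CCCC2)nc1Br` differs from compound 3 in one place bromo in place of chloro on an aromatic carbon with bromo in place of chloro on an aromatic carbon next to the ring nitrogen. The same exchange appears once among the measured pairs as a step that the two limits leave unreadable from compound 1 to compound 2 and so gives no size to carry over. The other measured step, pyrrolidin-1-yl in place of methylsulfanyl, is an at least 1.0-fold lower number from compound 1 to compound 3 (0.00 log units; that floor lies within the scatter) and says little about a halogen exchange.

With no readable precedent, the expected size is a 1.1-fold lower number from compound 3 to compound 4 (0.04 log units; within the scatter) and no change beyond the scatter is expected in this assay in either direction. The assay may well report only a limit for this compound. For compound 4 the estimate is 90000 nM with an expected range from 45000 nM to 170000 nM as the likely span.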

Compound 4, half-maximal inhibitory concentration: > 100000 nM
Compound 4: no number, only a limit (the forecaster's own chance of this, stated with the estimate: 40%); middle value at least 1.1-fold (0.04 log units) away from the limit.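

Going by these compounds, with the pyrrolidin-1-yl group in place, bromo in place of chloro on an aromatic carbon gets its first partly readable result in this assay, which gives an at least 1.0-fold higher number from compound 3 to compound 4 (0.00 log units; that floor lies within the scatter) and so shows no change beyond the scatter, while the true size stays unknown. The step from compound 2 to compound 4 cannot be read, as both ends are limits. Within the data shown here, compound 3 remains the only compound with an actual number, and the others stand at a limit: the limit of > 100000 nM in this assay, at which 3 of the 4 values shown sit.

On these data alone, how far the bromo compound really lies from the chloro compound stays open. Also open, as far as these compounds go, is whether a morpholin-4-yl group in place of the pyrrolidin-1-yl group, or an amine in place of the halogen, would bring values well inside the range of the assay.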